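Swapping a tert-butyl for a cyclopentyl ring

The compounds below may be only part of what the source reports. "The series", "measured", "known", "first", "only" and "open" are said of these compounds alone.

Compound 3, `C[C@@H](CNc1ccc(OC(F)(F)F)cc1)NC(=O)[C@@H](CC(=O)N1CCOCC1)CC(C)(C)C`, is the weakest inhibitor among the three compounds measured in an assay on isolated protein for inhibition of cathepsin S (Homo sapiens) (on this read-out higher numbers stand for weaker inhibition and lower numbers for stronger inhibition), where compound 3 gives 408 nM. Its nearest neighbour is compound 1, `C[C@@H](CNc1ccc(OC(F)(F)F)cc1)NC(=O)[C@H](CCC1CCCCC1)CC(=O)N1CCOCC1`, which in this assay gives 95 nM; furthest away is compound 2, `O=C(N[C@@H](CCc1ccccc1)CNc1ccc(OC(F)(F)F)cc1)[C@@H](CC(=O)N1CCOCC1)CC1CCCCC1`, which gives 18 nM. Within the data shown here, compound 1 and compound 3 share everything but one group, and the single step between them, a 4.3-fold higher number from compound 1 to compound 3 (0.63 log units; beyond the scatter), shows that replacing the cyclohexylmethyl with a tert-butyl weakened inhibition to a modest degree.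

Compound 4, `C[C@@H](CNc1ccc(OC(F)(F)F)cc1)NC(=O)[C@@H](CC(=O)N1CCOCC1)CC1CCCC1`, differs from compound 3 in one place: cyclopentyl in place of tert-butyl on a saturated chain carbon, two bonds along the chain from a carbonyl carbon. Among the measured compounds shown here, the only measured step that bears on this position is the one from compound 1 to compound 3, which points in the direction of a ring-containing group being favoured over a tert-butyl. Cyclopentyl restores a ring, though it is a smaller group than cyclohexylmethyl and sits one bond closer to the chain, so only part of that step is expected to be recovered.

The expected change is a 2.0-fold lower number from compound 3 to compound 4 (0.31 log units; beyond the scatter), a modest gain beyond the scatter. Compound 4 is therefore estimated at 200 nM, with a likely range from 80 nM to 500 nM.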

Compound 4, inhibition constant: 31 nM
Beside the measured number, compound 4's estimate is 6.5-fold (0.81 log units) above it; the measured number lies below the stated range.
By their numbers in this assay, from the lowest: compounds 2 and 4 (each within the scatter of the next); then compound 1; then compound 3.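

Changing tert-butyl to cyclopentyl on a saturated chain carbon, two bonds along the chain from a carbonyl carbon, gives a 13-fold lower number from compound 3 to compound 4 (1.12 log units; beyond the scatter) in this assay even though the two groups are close in size, with 4 heavy atoms in tert-butyl and 5 heavy atoms in cyclopentyl. This place therefore responds sharply to the shape of the group, not only to how much carbon it carries. Cyclopentyl also outperforms the earlier ring-bearing group, with cyclohexylmethyl giving way to it in a 3.1-fold lower number from compound 1 to compound 4 (0.49 log units; beyond the scatter) as a further gain, so the order among these groups is cyclopentyl, then cyclohexylmethyl, then tert-butyl, and no measurement here explains why that order arises.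

The compounds shown leave open how narrow this preference is, since neighbouring groups such as cyclobutyl, cyclohexyl attached directly, phenyl or an open isopropyl would show whether the five-membered ring itself is what counts. They also leave open whether cyclopentyl brings a similar gain on the core of compound 2, which carries a phenethyl-type chain where compound 4 has a methyl.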